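Shortening the Catechol Side Chain: Compound 1 to Compound 3

This account rests on a few compounds, and the source may have more. Where it says the series, first, only, none or still open, it means among the compounds named here.

Measured compounds:
compound 1, `COc1ccc(C2=C(c3ccc(SC)cc3)CC3CCCN3C2=O)cc1OC(=O)CNC(=O)OC(C)(C)C`, 20000 nM
compound 2, `CSc1ccc(C2=C(c3ccc(O)c(O)c3)C(=O)N3CCCC3C2)cc1`, 50000 nM

The two measured compounds share one core and were both tested in a functional assay on SW-620 cells (Homo sapiens) for cytotoxicity; on this read-out higher numbers stand for weaker inhibition of growth and lower numbers for stronger inhibition of growth. Compound 1 gives the lower of the two numbers, 20000 nM, while its nearest neighbour, compound 2, gives 50000 nM, a gap that lies beyond the usual scatter. Both numbers fall in a range where growth inhibition is weak.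

Compound 3, `COc1ccc(C2=C(c3ccc(SC)cc3)CC3CCCN3C2=O)cc1`, has not yet been measured in this assay. It differs from compound 1 in one place: a hydrogen atom in place of a group of 12 heavy atoms (7 carbon, 1 nitrogen, 4 oxygen; no ring), on an aromatic carbon. The group that leaves is a chain of 12 heavy atoms without a ring, carrying 1 hydrogen-bond donor and 4 hydrogen-bond acceptors, and it sits ortho to a methoxy group and meta to a large group.

Among the compounds with values here, no step between measured compounds matches this change, so the expectation rests on compound 1 alone. The account expects a modest move toward stronger growth inhibition in this assay, a 2.0-fold lower number from compound 1 to compound 3 (0.30 log units; within the scatter), though a step within the scatter would not surprise. Compound 3 is estimated at 10000 nM, with a range from 3000 nM to 40000 nM.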

Compound 3, concentration for 50% growth inhibition: 3000 nM
Beside the measured number, compound 3's estimate is 3.3-fold (0.52 log units) above it; measured number inside the range.
By their numbers in this assay, from the lowest: compound 3; then compound 1; then compound 2.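

With a hydrogen atom on this aromatic carbon in place of the chain, the read-out in this assay shows a 6.7-fold lower number from compound 1 to compound 3 (0.82 log units; beyond the scatter), which indicates that growth inhibition on these cells does not depend on the chain at this position, ortho to a methoxy group and meta to a large group. The change of 4-methoxyphenyl in place of 3,4-dihydroxyphenyl gives a 17-fold lower number from compound 2 to compound 3 (1.22 log units; beyond the scatter), which places compound 3 lowest of the three, with its steps to both other compounds beyond the scatter. Nothing in the data shown accounts for the size of either step.

From the compounds shown here alone, it remains open whether a smaller group on this aromatic carbon, such as a hydroxyl, a fluorine or an acetyl ester, would keep the number of compound 3 or move it back toward that of compound 1. Going by these compounds, it is also open whether a free amine at the end of a shorter chain would read differently from the protected chain of compound 1, and whether an ethoxy group in place of the methoxy group would change the number at all.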